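Benzylamine Sulfonamides Against Capan-2: Moving to Naphthalene

This account rests on a few compounds, and the source may have more. Where it says the series, first, only, none or still open, it means among the compounds named here.

Measured so far:
compound 1, `CC(C)(C)c1ccc(CNCCCNS(=O)(=O)c2cc(C(F)(F)F)cc(C(F)(F)F)c2)cc1`: 2100 nM
compound 2, `O=S(=O)(NCCCNCc1ccc(Br)cc1)c1cc(C(F)(F)F)cc(C(F)(F)F)c1`: 2000 nM

Both compounds share the same core and were tested in a functional assay on Capan-2 cells (Homo sapiens) for inhibition, read by MTT assay, with a stated time of 72 h; a higher number here means a weaker inhibitor of growth, a lower number a stronger inhibitor of growth. In this assay compound 1 gives 2100 nM and compound 2 gives 2000 nM. Among the compounds with values here, the single measured step, a 1.1-fold lower number from compound 1 to compound 2 (0.02 log units; within the scatter), exchanges one group on the aromatic ring at the end of the chain for another and leaves the number essentially unchanged. Within the data shown here, compound 2 therefore stands at a value that cannot be told apart from that of compound 1, the only other number available.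

Compound 3, `O=S(=O)(NCCCNCc1cccc2ccccc12)c1cc(C(F)(F)F)cc(C(F)(F)F)c1`, is not yet measured. It differs from compound 2 in that (naphthalen-1-yl in place of 4-bromophenyl on a saturated chain carbon bound to an amine nitrogen). Among the measured compounds shown here, the only step that bears on this is a 1.1-fold lower number from compound 1 to compound 2 (0.02 log units; within the scatter), which touches the same ring and was within the scatter; it gives no sign that this part of the molecule moves the number strongly, though a change of ring count is a larger alteration than a swap of substituent. For compound 3 the expected step is a 1.1-fold lower number from compound 2 to compound 3 (0.05 log units; within the scatter), that is none beyond the scatter. Compound 3 is therefore estimated at 1800 nM, within a range from 700 nM to 4500 nM.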

Compound 3, concentration for 50% growth inhibition: 2700 nM
For compound 3 the middle estimate is 1.5-fold (0.18 log units) below the measured one; low and high end bracket the measured number.
By their numbers in this assay, from the lowest: compounds 2, 1 and 3 (each within the scatter of the next).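

The second ring is the new information here. The earlier pair exchanged only a substituent on a single six-membered aromatic ring, whereas naphthalen-1-yl brings two such rings to the saturated chain carbon bound to an amine nitrogen, and in this assay this gives a 1.4-fold higher number from compound 2 to compound 3 (0.13 log units; within the scatter) and a 1.3-fold higher number from compound 1 to compound 3 (0.11 log units; within the scatter). Among these three compounds, then, neither replacement of the single substituted ring by the two-ring group moves the number beyond the scatter, and no compound among them goes against this, although the pattern extends no further than these three and gives them no order. Nothing available explains why the number holds across these groups.

The compounds shown leave open whether this place would respond to a group of a different kind, such as a benzyl group carrying a carboxylic acid or an amine, or a naphthalen-2-yl group in place of naphthalen-1-yl. They also leave open whether a longer chain between the two nitrogens, or any change to the shared core, would move the number beyond the scatter.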